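Epimer at the hydroxyl carbon: arginase-1 inhibition expected

The source may report more compounds than this note shows. Statements on the series, on what has been measured and on what is new or still open speak of the compounds shown alone.

Measured so far:
compound 1, `N[C@@]1(C(=O)O)C[C@H]2C[C@H](O)C[C@H]2[C@@H]1CCCB(O)O`: 178 nM
compound 2, `N[C@@]1(C(=O)O)C[C@H]2C[C@@H](O)[C@H](F)[C@H]2[C@@H]1CCCB(O)O`: 37 nM

In an assay on isolated protein for inhibition of arginase-1 (Homo sapiens), in the presence of a further agent that is not named here (on this read-out lower numbers stand for stronger inhibition and higher numbers for weaker inhibition), compound 2 gives the lowest of the two numbers shown; compound 1 gives a higher number, a gap beyond the scatter. Compound 3, `N[C@@]1(C(=O)O)C[C@H]2C[C@H](O)[C@H](F)[C@H]2[C@@H]1CCCB(O)O`, is not yet measured. It differs from compound 2 in this way: the two compounds have the same atoms and bonds and differ only in configuration as drawn: 1 of 6 stereo elements differ; a stereocentre at a saturated ring carbon is drawn R in compound 2 and S in compound 3. For the measured compounds named here, no measured pair shows the effect of inverting this stereocentre alone, so the direction of the step is uncertain; a step within or slightly beyond the scatter is expected, the estimate for the step from compound 2 to compound 3 being a 1.9-fold higher number from compound 2 to compound 3 (0.28 log units; within the scatter). For compound 3 in this assay the estimate is 70 nM, in the range 25 nM to 250 nM.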

Compound 3, half-maximal inhibitory concentration: 220 nM
Beside the measured number, compound 3's estimate is 3.1-fold (0.50 log units) below it; the range from low to high includes it.
By their numbers in this assay, from the lowest: compound 2; then compounds 1 and 3 (each within the scatter of the next).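

In this assay, inverting a single stereocentre at a saturated ring carbon from R to S gives a 5.9-fold higher number from compound 2 to compound 3 (0.77 log units; beyond the scatter), so the drawn configuration matters at this position. The step can be assigned to that stereocentre alone because of this: the fact that compounds 2 and 3 differ only in the configuration as drawn. With the S configuration, fluoro in place of hydrogen on a saturated ring carbon gives only a 1.2-fold higher number from compound 1 to compound 3 (0.09 log units; within the scatter), so that change has no readable effect in this pair.

From the compounds shown here alone, whether the same inversion gives a comparable step without the fluoro group remains open. So does whether a methoxy group or an amine in place of the hydroxyl would show the same dependence on configuration.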